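This account rests on a few compounds, and the source may have more. Where it says the series, first, only, none or still open, it means among the compounds named here.

Measured in a functional assay on HT-29 cells (Homo sapiens) for cytotoxicity, read by MTT assay, with a stated time of 72 h; on this read-out higher numbers stand for weaker inhibition and lower numbers for stronger inhibition:
- compound 1 `CN(C)CCn1cnnc1-c1cc(Oc2ccc(NC(=O)N/N=C/c3ccc(F)cc3Cl)cc2F)ccn1` gives 510 nM
- compound 2 `CN(C)CCn1cnnc1-c1cc(Oc2ccc(NC(=O)N/N=C/c3ccc(Cl)cc3)cc2F)ccn1` gives 530 nM
- compound 3 `Cc1cc(/C=N/NC(=O)Nc2ccc(Oc3ccnc(-c4nncn4CCN(C)C)c3)c(F)c2)cc(C)c1O` gives 1220 nM

Compound 1 has the lowest number of the three; compound 2 lies within the scatter of it (a 1.0-fold higher number from compound 1 to compound 2 (0.02 log units; within the scatter)), while compound 3 stands further off (a 2.4-fold higher number from compound 1 to compound 3 (0.38 log units; beyond the scatter)). Compound 4 `CN(C)CCn1cnnc1-c1cc(Oc2ccc(NC(=O)N/N=C/c3ccc(F)cc3F)cc2F)ccn1` is not yet measured in this assay. Relative to compound 1 it carries fluoro in place of chloro on an aromatic carbon. The closest measured step, from compound 1 to compound 2, also altered the ring on the carbon with a double bond to nitrogen and stayed within the scatter (a 1.0-fold higher number from compound 1 to compound 2 (0.02 log units; within the scatter)); the larger change to compound 3 moved the number only modestly (a 2.4-fold higher number from compound 1 to compound 3 (0.38 log units; beyond the scatter)). Swapping fluoro for chloro is therefore expected to give no step beyond the scatter. Compound 4 is estimated at 550 nM, with a range from 300 nM to 1000 nM. The expected step is a 1.1-fold higher number from compound 1 to compound 4 (0.03 log units; within the scatter).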

Compound 4, half-maximal inhibitory concentration: 960 nM
Compound 4: middle estimate off by 1.7-fold (0.24 log units), on the low side, within the range that was stated.
By their numbers in this assay, from the lowest: compounds 1, 2, 4 and 3 (each within the scatter of the next, the first and the last beyond it).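

In this assay, fluoro in place of chloro on this aromatic carbon, ortho to a large group, stays within the scatter (a 1.9-fold higher number from compound 1 to compound 4 (0.27 log units; within the scatter)), so this single-atom swap is tolerated here. Compound 4 also lies within the scatter of both other compounds (a 1.8-fold higher number from compound 2 to compound 4 (0.26 log units; within the scatter) and a 1.3-fold lower number from compound 3 to compound 4 (0.10 log units; within the scatter)), so it does not separate compound 1 from compound 3, which remain beyond the scatter of each other. Nothing available offers an explanation for this result. From the compounds shown here alone, whether a methoxy group or an amine at this position would move the number beyond the scatter remains open.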